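The source may hold more compounds than are shown below. What is called first, only, known or untested is meant among the compounds shown, and "the series" means these compounds.

Compound 3 `CCCCc1nc(C(=O)OC)nn1-c1ccc(F)cc1` gives 6400 nM in a functional assay on NCI-H226 cells (Homo sapiens) for inhibition, read by MTT assay, with a stated time of 72 h (a higher number here means a weaker inhibitor of growth, a lower number a stronger inhibitor of growth), the second highest of the three numbers recorded. Compound 2 `COC(=O)c1nc(C(C)C)n(-c2ccc(F)cc2)n1` gives 6170 nM in this assay, and compound 1 `CCc1nc(C(=O)OC)nn1-c1ccc(F)cc1` gives 71300 nM. There is a 1.0-fold higher number from compound 2 to compound 3 (0.02 log units; within the scatter), but an 11-fold lower number from compound 1 to compound 3 (1.05 log units; beyond the scatter).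

Compound 4 `COC(=O)c1nc(C2CC2)n(-c2ccc(F)cc2)n1` differs from compound 3 by cyclopropyl in place of butyl on an aromatic carbon. The two measured steps that bear on this are the flat one, a 1.0-fold higher number from compound 2 to compound 3 (0.02 log units; within the scatter), and the large one, an 11-fold lower number from compound 1 to compound 3 (1.05 log units; beyond the scatter). The shorter chain of compound 1 carries the much weaker number, so a modest rise is expected for compound 4 because an 11-fold lower number from compound 1 to compound 3 (1.05 log units; beyond the scatter) points that way, tempered because a 1.0-fold higher number from compound 2 to compound 3 (0.02 log units; within the scatter) shows little change between the two longer groups; the expected step is a 1.6-fold higher number from compound 3 to compound 4 (0.19 log units; within the scatter). Compound 4 is therefore estimated at 10000 nM, between 3500 nM and 30000 nM.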

Compound 4, concentration for 50% growth inhibition: 16300 nM
Compound 4: middle estimate off by 1.6-fold (0.21 log units), on the low side; the measured number falls inside the stated range.
By their numbers in this assay, from the lowest: compounds 2 and 3 (each within the scatter of the next); then compound 4; then compound 1.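

At the aromatic carbon between two ring nitrogen atoms, the ring of cyclopropyl separates from both open groups that had stood level in this assay: the result is a 2.5-fold higher number from compound 3 to compound 4 (0.41 log units; beyond the scatter) and a 2.6-fold higher number from compound 2 to compound 4 (0.42 log units; beyond the scatter). Cyclopropyl nevertheless keeps an advantage over ethyl, with a 4.4-fold lower number from compound 1 to compound 4 (0.64 log units; beyond the scatter) in the same assay, so it falls inside the range the open groups span. Nothing measured here accounts for these differences.

From the compounds shown here alone, whether cyclobutyl, a longer chain such as hexyl or an amine on this carbon would shift the number further remains open. So does whether this order holds with a carboxylic acid in place of the methoxycarbonyl group.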